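Swapping a Methoxyphenyl for Thiophenyl on a Cyanopyridine Core

This account rests on a few compounds, and the source may have more. Where it says the series, first, only, none or still open, it means among the compounds named here.

Measured compounds:
- compound 1 `CCOc1nc(-c2nc3ccccc3n2C)cc(-c2ccc(F)cc2)c1C#N`: 362000 nM
- compound 2 `CCOc1nc(-c2nc3ccccc3n2C)cc(-c2ccc(OC)cc2)c1C#N`: 436000 nM

Both values come from a functional assay on aorta (Rattus norvegicus, strain Wister); a higher number here means a weaker inhibitor, a lower number a stronger inhibitor. Among the compounds with values here, compound 2 gives the highest number of the two, but its only neighbour is compound 1, and the step of a 1.2-fold higher number from compound 1 to compound 2 (0.08 log units; within the scatter) lies within the scatter, so the two compounds cannot be told apart on these numbers.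

Compound 3 `CCOc1nc(-c2nc3ccccc3n2C)cc(-c2cccs2)c1C#N` has not yet been measured in this assay. It differs from compound 2 in one place: thiophen-2-yl in place of 4-methoxyphenyl on an aromatic carbon. Within the data shown here, the one measured step, a 1.2-fold higher number from compound 1 to compound 2 (0.08 log units; within the scatter), changed a small group on the same aromatic ring that is now replaced altogether, and that step stayed within the scatter. Among the measured compounds shown here, no measured step replaces the whole ring, so there is no direct precedent for this change.

In the absence of such a precedent, the expectation for compound 3 in this assay is a step of a 1.1-fold lower number from compound 2 to compound 3 (0.04 log units; within the scatter), that is, no change beyond the scatter. Compound 3 is therefore estimated at 400000 nM, with a range from 130000 nM to 1200000 nM.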

Compound 3, half-maximal inhibitory concentration: 249000 nM
Estimate against measurement, compound 3: 1.6-fold (0.21 log units) above; low and high end bracket the measured number.
By their numbers in this assay, from the lowest: compounds 3, 1 and 2 (each within the scatter of the next).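

In this assay, exchanging the whole 4-methoxyphenyl ring for the smaller, five-membered thiophen-2-yl ring at the position opposite the ring nitrogen gives a 1.8-fold lower number from compound 2 to compound 3 (0.24 log units; within the scatter), and exchanging 4-fluorophenyl for the same thiophen-2-yl gives a 1.5-fold lower number from compound 1 to compound 3 (0.16 log units; within the scatter). Within the data shown here, the earlier pair showed only that a small group on the six-membered ring could be changed within the scatter, whereas these two steps show the same for replacing the ring itself, including a sulfur-containing ring in place of a ring of carbon only. Nothing measured here offers an explanation for this result.

The compounds shown all carry an aromatic ring at this position, so it remains open whether a non-aromatic group such as an amine, a carboxylic acid or a longer alkyl chain would give a number that differs beyond the scatter. Also open, from the compounds shown here alone, is whether a change at the ethoxy group or the nitrile on the shared core would move the number more than these ring exchanges do.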